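Replacing 3-fluoro-4-methoxyphenyl with 4-chlorophenyl on the shared core

The compounds below may be only part of what the source reports. "The series", "measured", "known", "first", "only" and "open" are said of these compounds alone.

In a functional assay on A549 cells (Homo sapiens) for antiproliferative activity, read by MTT assay, with a stated time of 48 h (a lower number here means a stronger inhibitor, a higher number a weaker inhibitor), compound 2 `COc1ccc(-c2nc3cccc(-c4cc(OC)c(OC)c(OC)c4)c3o2)cc1F` gives 1800 nM. Compound 1 `COc1cccc(-c2nc3cccc(-c4cc(OC)c(OC)c(OC)c4)c3o2)c1` gives 3500 nM, and the two stand level, with a 1.9-fold lower number from compound 1 to compound 2 (0.29 log units; within the scatter). Compound 3 `COc1cc(-c2cccc3nc(-c4ccc(Br)cc4)oc23)cc(OC)c1OC` reports only a limit, > 25000 nM.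

Compound 4 `COc1cc(-c2cccc3nc(-c4ccc(Cl)cc4)oc23)cc(OC)c1OC` differs from compound 2 in one place, with 4-chlorophenyl in place of 3-fluoro-4-methoxyphenyl on an aromatic carbon. The closest measured change is the move to 4-bromophenyl in compound 3, which gives an at least 13-fold higher number from compound 2 to compound 3 (1.14 log units; beyond the scatter). The change from the other measured compound points the same way, with an at least 7.1-fold higher number from compound 1 to compound 3 (0.85 log units; beyond the scatter). For the measured compounds named here, no compound carrying 4-chlorophenyl has been measured, so the expectation rests on compound 3 alone. A large step toward a higher number is therefore expected in this assay, and the assay may again report only a limit. The expected size of the change is an 11-fold higher number from compound 2 to compound 4 (1.05 log units; beyond the scatter). Compound 4 is estimated at 20000 nM, with an expected range from 7000 nM to 60000 nM.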

Compound 4, half-maximal inhibitory concentration: 5600 nM
Compound 4: the middle estimate sits 3.6-fold (0.55 log units) above what was measured; measured number outside the range, below it.
By their numbers in this assay, from the lowest: compounds 2, 1 and 4 (each within the scatter of the next, the first and the last beyond it). At a limit, above all of these: compound 3.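

In this assay, the halogen makes a clear difference on this ring, with chloro in place of bromo giving an at least 4.4-fold lower number from compound 3 to compound 4 (0.64 log units; beyond the scatter), so the drop seen with compound 3 does not carry over in full to every halogen. Compound 3 reports only a limit, not a number: the limit of > 25000 nM in this assay, at which 1 of the 4 values shown sits. Against the two methoxy-bearing groups, 4-chlorophenyl gives a mixed picture, with a modest rise of a 3.1-fold higher number from compound 2 to compound 4 (0.49 log units; beyond the scatter) but no separation in a 1.6-fold higher number from compound 1 to compound 4 (0.20 log units; within the scatter), so a hydrogen-bond acceptor on this ring is not required for a number in this range.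

Going by these compounds, how large the step from chloro to bromo really is stays open while compound 3 remains at a limit. The compounds shown also leave open how a fluoro group, an amine or a carboxylic acid in place of the chloro would read.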